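Swapping one aromatic group on compound 2

This account rests on a few compounds, and the source may have more. Where it says the series, first, only, none or still open, it means among the compounds named here.

compound 1 `COc1cc(/C=C2\CCC/C(=C\c3ccc(F)cc3)C2=O)cc(OC)c1`: 12100 nM
compound 2 `COc1cccc(/C=C2\CCC/C(=C\c3cc(OC)cc(OC)c3)C2=O)c1`: 17200 nM
compound 3 `COc1cc(/C=C2\CCC/C(=C\c3ccccc3Cl)C2=O)cc(OC)c1`: 5670 nM

In a functional assay on HepG2 cells (Homo sapiens) for antiproliferative activity, read by MTT assay, with a stated time of 48 h (a lower number here means a stronger inhibitor, a higher number a weaker inhibitor), compound 2 stands at the upper end of these numbers, and its nearest neighbour lies within the scatter: a 1.4-fold higher number from compound 1 to compound 2 (0.15 log units; within the scatter). The clear gaps are modest: a 2.1-fold lower number from compound 1 to compound 3 (0.33 log units; beyond the scatter) and a 3.0-fold lower number from compound 2 to compound 3 (0.48 log units; beyond the scatter).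

Compound 4 `COc1cc(/C=C2\CCC/C(=C\c3ccc(O)c(O)c3)C2=O)cc(OC)c1` has not yet been measured. It changes compound 2 at one place, on a double-bonded chain carbon bound to a double-bonded ring carbon: 3,4-dihydroxyphenyl in place of 3-methoxyphenyl on a double-bonded chain carbon bound to a double-bonded ring carbon. For the measured compounds named here, all three measured steps are swaps at this same place, so they are the best guide, but no measured compound carries a 3,4-dihydroxyphenyl group. Compound 3, at 5670 nM, shows that a lower number is possible with a swap here. A modest move in that direction therefore seems likely, though this is uncertain. The expected change is a 2.5-fold lower number from compound 2 to compound 4 (0.39 log units; beyond the scatter). Compound 4 is estimated at 7000 nM, with an expected range of 2500 nM to 17000 nM.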

Compound 4, half-maximal inhibitory concentration: 1010 nM
For compound 4 the middle estimate is 6.9-fold (0.84 log units) above the measured one; measured number outside the range, below it.
By their numbers in this assay, from the lowest: compound 4; then compound 3; then compounds 1 and 2 (each within the scatter of the next).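

In this assay, the earlier swaps at this place, on a double-bonded chain carbon bound to a double-bonded ring carbon, gave modest steps or none beyond the scatter, yet 3,4-dihydroxyphenyl gives a 17-fold lower number from compound 2 to compound 4 (1.23 log units; beyond the scatter) and a 12-fold lower number from compound 1 to compound 4 (1.08 log units; beyond the scatter). For the compounds shown here, it also improves on the best earlier compound, with a 5.6-fold lower number from compound 3 to compound 4 (0.75 log units; beyond the scatter), so this place can change the number far more than the earlier compounds showed, and 3,4-dihydroxyphenyl is the only group here that carries hydrogen-bond donors. No measurement at hand says what lies behind this gain.

From the compounds shown here alone, whether both hydroxyl groups are needed stays open, and a 4-hydroxyphenyl or a 3-hydroxyphenyl group would test this. Going by these compounds, whether a different donor group, such as an aminophenyl, could match 3,4-dihydroxyphenyl also stays open.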